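Bromo for hydrogen on the phenyl ring: tolerance outlook

The source may hold more compounds than are shown below. What is called first, only, known or untested is meant among the compounds shown, and "the series" means these compounds.

Three hydrazones on one shared core have been measured in an ADME assay on MT4 cells (Homo sapiens) for cytotoxicity, read by MTT assay, with a stated time of 4 days; a lower number here means that less compound is tolerated, a higher number that more compound is tolerated. Compound 1 `O=C(COc1cccc2ccccc12)N/N=C/c1cccc(O)c1` gives 32.6 ug/mL and compound 2 `O=C(COc1cccc2ccccc12)N/N=C/c1ccccc1O` gives 5.19 ug/mL. Compound 3 `O=C(COc1cccc2ccccc12)N/N=C/c1ccccc1` gives only a limit of the assay in this assay, >= 96.6 ug/mL. Compound 3 thus stands at the top of the numbers shown, sitting at the limit of >= 96.6 ug/mL in this assay, at which 1 of the 3 values shown sits; both steps that end at it, an at least 2.9-fold higher number from compound 1 to compound 3 (0.47 log units; beyond the scatter) and an at least 18-fold higher number from compound 2 to compound 3 (1.26 log units; beyond the scatter), run toward a higher number, while the step of a 6.3-fold lower number from compound 1 to compound 2 (0.80 log units; beyond the scatter) lies between the two hydroxy compounds.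

Compound 4 `O=C(COc1cccc2ccccc12)N/N=C/c1cccc(Br)c1` differs from compound 3 by bromo in place of hydrogen on an aromatic carbon. The measured steps that touch this ring concern hydroxy only, so they tell where a substituent has mattered but nothing about bromo itself. With compound 3 already at the limit, a further rise cannot be read from the numbers, and a fall would have to come from the bromo group, for which no comparison exists here. Compound 4 is expected to stay near the limit, with the step of an at least 1.3-fold lower number from compound 3 to compound 4 (0.13 log units; that floor lies within the scatter) expected to fall within the scatter or run modestly downward. The estimate for compound 4 is 70 ug/mL, in the range 20 ug/mL to 120 ug/mL.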

Compound 4, half-maximal cytotoxic concentration: 87.4 ug/mL
The estimate for compound 4 lay 1.2-fold (0.10 log units) below the measured number; low and high end bracket the measured number.
By their numbers in this assay, from the lowest: compound 2; then compound 1; then compound 4. At a limit, above all of these: compound 3.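

In this assay, a substituent at this place on the ring need not bring the number down: bromo in place of hydroxy gives a 2.7-fold higher number from compound 1 to compound 4 (0.43 log units; beyond the scatter), and 3-bromophenyl in place of 2-hydroxyphenyl gives a 17-fold higher number from compound 2 to compound 4 (1.23 log units; beyond the scatter). The low numbers of the two hydroxy compounds therefore do not extend to bromo, and against the unsubstituted phenyl, bromo in place of hydrogen gives an at least 1.1-fold lower number from compound 3 to compound 4 (0.04 log units; that floor lies within the scatter), so no real fall can be claimed from this step. The value of compound 3 remains a limit of the assay and not a number: the limit of >= 96.6 ug/mL in this assay, at which 1 of the 4 values shown sits.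

On these data alone, the true size of the step from hydrogen to bromo stays open, since the limit hides how far compound 3 would lie from compound 4. Also open, as far as these compounds go, is whether the tolerance seen with bromo holds for other groups at this place, such as an amine, a carboxylic acid or a methoxy group, or whether the low numbers are particular to hydroxy.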